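Fluoro to chloro on the phenyl of compound 3

A few compounds are considered here, and "the series" means these few. Any claim that something is new, unique, unknown or untested is made for them only; others in the source may bear on it.

Measured in a functional assay on MDA-MB-468 cells (Homo sapiens) for inhibition, read by sulforhodamine B assay, with a stated time of 48 h, tested at 10 uM; on this read-out higher numbers stand for more inhibition at the one concentration tested (going by the name of the read-out) and lower numbers for less inhibition:
compound 1, `Brc1cn2ccnc2c(-c2ccc3ncn(C4CCCCC4)c3c2)n1`, gives 44.4%
compound 2, `c1ccc(-c2cn3ccnc3c(-c3ccc4ncn(C5CCCCC5)c4c3)n2)cc1`, gives 54.4%
compound 3, `Fc1ccc(-c2cn3ccnc3c(-c3ccc4ncn(C5CCCCC5)c4c3)n2)cc1`, gives 19.5%

Compound 3 stands lowest of the three in this assay; its nearest neighbour is compound 1, and both steps leading to compound 3 lie beyond the scatter: a number 24.9 percentage points lower from compound 1 to compound 3 (beyond the scatter) and a number 34.9 percentage points lower from compound 2 to compound 3 (beyond the scatter). The step of a number 10 percentage points higher from compound 1 to compound 2 (within the scatter) stays within the scatter.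

Compound 4, `Clc1ccc(-c2cn3ccnc3c(-c3ccc4ncn(C5CCCCC5)c4c3)n2)cc1`, differs from compound 3 by chloro in place of fluoro on an aromatic carbon. Among the measured compounds shown here, no measured step exchanges one halogen for another on this phenyl. For the measured compounds named here, the only step touching the same place, a number 34.9 percentage points lower from compound 2 to compound 3 (beyond the scatter), shows that what sits on the aromatic carbon para to a large group can move the number by a large amount, but it gives no direction for chloro against fluoro. A number somewhere between the figure of compound 3 and the figures of compound 1 and compound 2 is the expectation, with wide uncertainty. For compound 4 the expected step is a number 10.5 percentage points higher from compound 3 to compound 4 (beyond the scatter). The estimate for compound 4 is 30%, in the range 10% to 50%.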

Compound 4, a percentage reported as inhibition, at one concentration (the size of the read-out at that concentration, not a potency): 10.6%
Compound 4: middle estimate off by 19.4 percentage points, on the high side; the range from low to high includes it.
By their numbers in this assay, from the lowest: compounds 4 and 3 (each within the scatter of the next); then compounds 1 and 2 (each within the scatter of the next).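

Fluoro and chloro on this phenyl cannot be told apart: compound 3 and compound 4 read alike in this assay (a number 8.9 percentage points lower from compound 3 to compound 4 (within the scatter)). The low number therefore does not rest on fluoro alone, since the chloro compound also stands well away from the unsubstituted phenyl and the bromo compound, with a number 43.8 percentage points lower from compound 2 to compound 4 (beyond the scatter) and a number 33.8 percentage points lower from compound 1 to compound 4 (beyond the scatter) in the same direction as the steps to compound 3. Nothing at hand accounts for this fall on placing a halogen at this position.

As far as these compounds go, whether the low number belongs to halogens only or to any group on this aromatic carbon stays open; a methoxy, an amine or a carboxylic acid there would separate those readings. From the compounds shown here alone, with one concentration per compound, potency also stays open.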